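The compounds below may be only part of what the source reports. "The series", "measured", "known", "first", "only" and "open" are said of these compounds alone.

Measured in a functional assay on PC-3 cells (Homo sapiens) for cytotoxicity, read by WST assay, with a stated time of 72 h; a higher number here means a weaker inhibitor, a lower number a stronger inhibitor:
- Compound 1 `O=C1Nc2c(ccc(F)c2F)C1(c1ccc(O)cc1)c1ccc(F)cc1`: 8.6 nM
- Compound 2 `Cc1ccc(C2(c3ccc(O)cc3)C(=O)Nc3c2ccc(F)c3F)cc1`: 0.8 nM
- Compound 3 `CCCOc1ccc(C2(c3ccc(O)cc3)C(=O)Nc3c2ccc(F)c3F)cc1`: > 1000 nM, which is a limit of the assay

Compound 2 holds the lower of the two true numbers in the series, with compound 1 as its nearest neighbour. The step followed here leads to compound 4 `O=C1Nc2c(ccc(F)c2F)C1(c1ccc(O)cc1)c1ccc(F)c(F)c1`: 3,4-difluorophenyl in place of 4-methylphenyl on a saturated ring carbon.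

The closest measured precedent is an 11-fold lower number from compound 1 to compound 2 (1.03 log units; beyond the scatter), with methyl in place of fluoro on an aromatic carbon. Read in reverse, it suggests that leaving methyl for fluoro costs a large step. The propoxy steps, an at least 110-fold higher number from compound 1 to compound 3 (2.06 log units; beyond the scatter) and an at least 1200-fold higher number from compound 2 to compound 3 (3.09 log units; beyond the scatter), are also large, but they bear on this change only loosely. They show that changes on this aromatic ring can move the number strongly.

A large step in this assay towards a higher number is therefore expected. This expectation rests on compound 1 at 8.6 nM, since compound 4 keeps a fluoro group on that ring. The series holds no measured case of an added fluoro, so the range stays wide.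

The expected step is an 11-fold higher number from compound 2 to compound 4 (1.05 log units; beyond the scatter).

Compound 4 is estimated at 9 nM, with an expected range of 2.5 nM to 35 nM.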

Compound 4, half-maximal inhibitory concentration: 19 nM
Compound 4: middle estimate off by 2.1-fold (0.32 log units), on the low side; low and high end bracket the measured number.
By their numbers in this assay, from the lowest: compound 2; then compound 1; then compound 4. At a limit, above all of these: compound 3.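

In this assay the exchange on the saturated ring carbon gives a 24-fold higher number from compound 2 to compound 4 (1.38 log units; beyond the scatter) and shows that the 3,4-difluorophenyl group does not keep the low number reached with the 4-methylphenyl group. Among these compounds, the fluoro added to the ring of compound 1 gives a 2.2-fold higher number from compound 1 to compound 4 (0.34 log units; beyond the scatter) and is the first measured case of an added fluoro on this aromatic ring; it is a modest step, and it does not bring back the number of compound 2. Set against an 11-fold lower number from compound 1 to compound 2 (1.03 log units; beyond the scatter), it places most of the distance from compound 2 to compound 4 in the loss of methyl and the smaller part in the added fluoro, a reading that rests on these three compounds alone.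

Going by these compounds, how an ethyl group, a methoxy group or an amine on this aromatic ring would compare with methyl and propoxy remains open, as does the effect of a methyl group kept alongside the added fluoro. Nothing measured in the compounds shown accounts for either new step.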